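A few compounds are considered here, and "the series" means these few. Any claim that something is new, unique, unknown or untested is made for them only; others in the source may bear on it.

Measured compounds in a functional assay on PC-3 cells (Homo sapiens) for cytotoxicity, read by MTT assay, with a stated time of 48 h; on this read-out lower numbers stand for stronger inhibition and higher numbers for weaker inhibition:
compound 1 `CCCNCC(=O)N1N=C(c2cc3ccccc3oc2=O)CC1c1ccccc1` gives 7270 nM
compound 2 `O=C(CNC1CCCCC1)N1N=C(c2cc3ccccc3oc2=O)CC1c1ccccc1` gives 48500 nM
compound 3 `CCN(CC)C1CCN(CC(=O)N2N=C(c3cc4ccccc4oc3=O)CC2c2ccccc2)CC1` gives 26100 nM

Compound 3 stands second highest of the three numbers in this assay. Its nearest neighbour is compound 2, separated by a 1.9-fold lower number from compound 2 to compound 3 (0.27 log units; within the scatter), a gap within the scatter; its furthest is compound 1, separated by a 3.6-fold higher number from compound 1 to compound 3 (0.56 log units; beyond the scatter), a gap beyond the scatter.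

Compound 4 `O=C(CN1CCC(O)CC1)N1N=C(c2cc3ccccc3oc2=O)CC1c1ccccc1` differs from compound 3 by hydroxy in place of diethylamino on a saturated ring carbon. Within the data shown here, no measured step alters the group on the piperidine ring in this way, so no direct precedent exists. The two steps that involve the 4-(diethylamino)piperidin-1-yl group, a 3.6-fold higher number from compound 1 to compound 3 (0.56 log units; beyond the scatter) and a 1.9-fold lower number from compound 2 to compound 3 (0.27 log units; within the scatter), were modest or within the scatter, and the third, a 6.7-fold higher number from compound 1 to compound 2 (0.82 log units; beyond the scatter), was modest as well; the whole series spans a narrow band. Compound 4 is therefore expected to fall within that same band, with at most a modest movement in either direction, and the step of a 1.3-fold lower number from compound 3 to compound 4 (0.12 log units; within the scatter) is the estimated outcome. Compound 4 is expected to give 20000 nM in this assay, with a range from 7000 nM to 60000 nM.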

Compound 4, half-maximal inhibitory concentration: "not active" (no number reported)
Compound 4 has no reported number here, so the estimate cannot be set against anything.
By their numbers in this assay, from the lowest: compound 1; then compounds 3 and 2 (each within the scatter of the next).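

Among these compounds, compound 4 is reported in this assay as not active, with no number, so no step from compound 3 or any other compound to compound 4 can be read. The compounds shown leave open how far 4-hydroxypiperidin-1-yl in compound 4 separates it from compound 3 in this assay. No other data shown here bear on this result.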